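A few compounds are considered here, and "the series" means these few. Any claim that something is new, unique, unknown or untested is made for them only; others in the source may bear on it.

Measured so far in a functional assay on HEK293 cells for agonist activity at Free fatty acid receptor 1 (Homo sapiens), read by fluorescence and calcium flux, with a stated time of 10 min; a higher number here means a larger maximal response, a lower number a smaller maximal response:
compound 1 `CS(=O)(=O)CCCOc1ccc2c(c1)OC(COc1ccc(CCC(=O)O)c(F)c1)CC2` — 38%
compound 2 `O=C(O)CCc1ccc(OCC2COc3cc(Br)ccc3O2)cc1F` — 67%
compound 3 `CC#CC(CC(=O)O)c1ccc(OCC2COc3ccc(Cl)cc3O2)cc1` — 104%

Compound 3 stands highest of these three numbers in this assay; compound 2 lies lower by a gap beyond the scatter, and compound 1 lower still, also beyond the scatter. Compound 4 `Cn1cncc1C(CC(=O)O)c1ccc(OCC2COc3ccc(Cl)cc3O2)cc1` has not yet been measured. It differs from compound 3 in one place: 1-methyl-1H-imidazol-5-yl in place of prop-1-yn-1-yl on a saturated chain carbon bound to an aromatic carbon and a saturated chain carbon. Among the measured compounds shown here, no step between two measured compounds isolates a change of this kind, so the expectation rests on compound 3 alone and carries wide uncertainty. A moderate decrease in this assay is expected, since the maximal response of compound 3 leaves little room upward. For compound 4 the expected value is 85%, between 55% and 115%. The expected step of a number 19 percentage points lower from compound 3 to compound 4 (beyond the scatter) is a drop somewhat beyond the scatter.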

Compound 4, largest response reached (Emax), in percent of the reference or control that the assay uses: 62%
For compound 4 the middle estimate is 23 percentage points above the measured one, within the range that was stated.
By their numbers in this assay, from the lowest: compound 1; then compounds 4 and 2 (each within the scatter of the next); then compound 3.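

Among the compounds shown here, replacing prop-1-yn-1-yl with 1-methyl-1H-imidazol-5-yl on the saturated chain carbon bound to an aromatic carbon and a saturated chain carbon gives, in this assay, a number 42 percentage points lower from compound 3 to compound 4 (beyond the scatter) and is the first single-place exchange. The maximal response is thus sensitive to the group at this position, although compound 4 still reaches 62% in this assay. No measurement at hand accounts for the loss.

On these data alone, whether phenyl, pyridin-3-yl or a plain methyl group at this carbon would keep the response of compound 3 remains open. Also open, as far as these compounds go, is whether 1-methyl-1H-imidazol-5-yl would cause a similar loss on the fluorinated propanoic acid compounds.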